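Aminoquinoxaline benzylamines against a breast cancer cell line

This account rests on a few compounds, and the source may have more. Where it says the series, first, only, none or still open, it means among the compounds named here.

Measured compounds:
- compound 1, `CCOC(=O)[C@H](CCC(=O)O)NC(=O)c1ccc(CNc2nc3cc(N)cc(N)c3nc2-c2ccccc2)cc1`: 26300 nM
- compound 2, `Nc1cc(N)c2nc(-c3ccccc3)c(NCc3ccc(Cl)c(Cl)c3)nc2c1`: 1580 nM
- compound 3, `CCOC(=O)[C@H](CCC(=O)O)NC(=O)c1ccc(Sc2nc3cc(N)cc(N)c3nc2-c2ccccc2)cc1`: 7940 nM

Three compounds sharing one core were tested in a functional assay on MDA-MB-231 cells (Homo sapiens) for inhibition, read by sulforhodamine B assay, with a stated time of 48 h; on this read-out higher numbers stand for weaker inhibition of growth and lower numbers for stronger inhibition of growth. Compound 2 gives 1580 nM and stands lowest of the three, the strongest inhibitor of growth, as its gaps to compound 3 and to compound 1 both lie beyond the scatter. Compound 3, carrying a glutamate-bearing benzoyl linked through sulfur, gives 7940 nM, and compound 1, with the same glutamate arm linked through an aminomethyl bridge, gives 26300 nM.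

Compound 4, `COc1ccc(CNc2nc3cc(N)cc(N)c3nc2-c2ccccc2)cc1`, is not yet measured. It differs from compound 2 in one place: 4-methoxyphenyl in place of 3,4-dichlorophenyl on a saturated chain carbon bound to a nitrogen on an aromatic ring. Within the data shown here, no pair of measured compounds shows this kind of change, so the expectation rests only on compound 2 and the general spread seen among the three. The step from compound 2 to compound 4 in this assay is estimated as a modest weakening, a 2.5-fold higher number from compound 2 to compound 4 (0.40 log units; beyond the scatter), toward a higher number. For compound 4 the expected value in this assay is 4000 nM, within a range from 1300 nM to 12000 nM.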

Compound 4, concentration for 50% growth inhibition: 2880 nM
For compound 4 the middle estimate is 1.4-fold (0.14 log units) above the measured one, within the range that was stated.
By their numbers in this assay, from the lowest: compounds 2 and 4 (each within the scatter of the next); then compound 3; then compound 1.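

In this assay the change from 3,4-dichlorobenzyl to 4-methoxybenzyl gives a 1.8-fold higher number from compound 2 to compound 4 (0.26 log units; within the scatter), so the two aryl groups cannot be told apart at this position on a saturated chain carbon bound to a nitrogen on an aromatic ring. The earlier compounds shown here offered no step here; this one shows that the two chlorine atoms can leave and a methoxy group can enter without a difference beyond the scatter. The data shown offer no explanation for this result.

Going by these compounds, whether an unsubstituted phenyl, a 4-chlorophenyl or a 4-aminophenyl at this place would also stay within the scatter remains open. Also open is how a carboxylic acid placed directly on this benzyl ring would read, since the only other arm shown on an aminomethyl bridge is the glutamate-bearing benzoyl of compound 1.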